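Fluoro and trifluoromethyl substituents in a small cytotoxicity series

This account rests on a few compounds, and the source may have more. Where it says the series, first, only, none or still open, it means among the compounds named here.

Compound 1 `CC1=C(/C=C/C(=O)/C=C/c2ccccc2)C(C)(C)CCC1O`: 8000 nM
Compound 2 `CC1=C(/C=C/C(=O)/C=C/c2cccc(C(F)(F)F)c2)C(C)(C)CCC1O`: 1700 nM
Compound 3 `CC1=C(/C=C/C(=O)/C=C/c2ccccc2F)C(C)(C)CCC1O`: 3300 nM

In a functional assay on CWR22R cells (Homo sapiens) for cytotoxicity, read by MTT assay, with a stated time of 72 h (on this read-out lower numbers stand for stronger inhibition and higher numbers for weaker inhibition), compound 1 gives 8000 nM, compound 2 gives 1700 nM, and compound 3 gives 3300 nM. Compound 2 differs from compound 1 by trifluoromethyl in place of hydrogen on an aromatic carbon, a change that gave a 4.7-fold lower number from compound 1 to compound 2 (0.67 log units; beyond the scatter). Compound 3 differs from compound 1 by fluoro in place of hydrogen on an aromatic carbon, which gave a 2.4-fold lower number from compound 1 to compound 3 (0.38 log units; beyond the scatter). The values of compound 2 and compound 3 lie within the scatter of each other.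

Compound 4 `CC1=C(/C=C/C(=O)/C=C/c2ccc(C(F)(F)F)cc2F)C(C)(C)CCC1O` has not yet been measured. It differs from compound 3 by trifluoromethyl in place of hydrogen on an aromatic carbon. This is the same kind of change as that from compound 1 to compound 2, but not the same: in compound 2 the trifluoromethyl is meta to a large group, whereas in compound 4 it is meta to a fluoro group and para to a large group. The cores of compound 4 and compound 2 differ as described by fluoro in place of hydrogen on an aromatic carbon.

Because the step of a 4.7-fold lower number from compound 1 to compound 2 (0.67 log units; beyond the scatter) was modest but beyond the scatter, compound 4 is expected to show a step of about a 3.7-fold lower number from compound 3 to compound 4 (0.56 log units; beyond the scatter) in this assay, with some allowance for the different place. Compound 4 is therefore estimated at 900 nM, expected to fall between 300 nM and 3000 nM.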

Compound 4, half-maximal inhibitory concentration: 3800 nM
Compound 4: the middle estimate sits 4.2-fold (0.63 log units) below what was measured; measured number above the stated range.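

In this assay, trifluoromethyl in place of hydrogen on an aromatic carbon of the core of compound 3 gave a 1.2-fold higher number from compound 3 to compound 4 (0.06 log units; within the scatter), so this step shows no change on that core. The same kind of change therefore did not carry over with the same size from one core to the other: the same change on two cores in this assay, a 4.7-fold lower number (0.67 log units; beyond the scatter) from compound 1 to compound 2 and a 1.2-fold higher number (0.06 log units; within the scatter) from compound 3 to compound 4, 5.4-fold (0.73 log units) apart, beyond the scatter of two such steps This does not show why the steps differ, as the two pairs differ both in the fluoro group on the core and in where the trifluoromethyl sits, and two pairs cannot separate these two differences.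

The compounds shown leave open what trifluoromethyl would do on the core of compound 3 in the place it holds in compound 2, and what it would do on the core of compound 1 in the place it holds in compound 4. They also leave open how other groups on the same ring, such as a methoxy group, a nitrile or an amine, would behave on either core.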